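This account rests on a few compounds, and the source may have more. Where it says the series, first, only, none or still open, it means among the compounds named here.

The measured compounds:

Compound 1, `O=C(O)c1csc(-n2nc(-c3ccccc3)c3c2CCCC3)n1`, gives 16 nM in an assay on isolated protein for antagonist activity at prostaglandin E2 receptor EP1 subtype (Homo sapiens), read by reporter gene assay; a lower number here means a stronger inhibitor, a higher number a weaker inhibitor.
Compound 2, `O=C(O)c1csc(-n2nc(-c3ccccc3)c3c2CCCCC3)n1`, gives 1000 nM in this assay.
Compound 3, `O=C(O)c1csc(-n2nc(-c3cccc(F)c3)c3ccccc32)n1`, gives 20 nM in this assay.

All three share the carboxy-substituted thiazole attached to a ring nitrogen of a fused bicyclic core and differ in the saturated or aromatic ring fused to that core and in the group on the aromatic carbon of the five-membered ring. Compound 3 stands second highest of the three numbers. Its nearest neighbour is compound 1, whose value lies within the usual scatter of compound 3, so no order can be read between them. The furthest is compound 2, whose value lies well beyond the scatter above that of compound 3.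

Compound 4, `CC1CCN(c2nn(-c3nc(C(=O)O)cs3)c3ccccc23)CC1`, is not yet measured. It differs from compound 3 in one place: 4-methylpiperidin-1-yl in place of 3-fluorophenyl on an aromatic carbon. Among the measured compounds shown here, no measured pair shows this kind of exchange, an aromatic ring for a saturated nitrogen-containing ring, so the direction of the step cannot be read from the data. The author expects compound 4 to be weaker than compound 3, with the step from compound 3 to compound 4 estimated at a 5.0-fold higher number from compound 3 to compound 4 (0.70 log units; beyond the scatter). Compound 4 is therefore expected to give about 100 nM, in a range from 20 nM to 500 nM.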

Compound 4, half-maximal inhibitory concentration: 32 nM
The estimate for compound 4 lay 3.1-fold (0.49 log units) above the measured number, and the stated range covers the measured number.
By their numbers in this assay, from the lowest: compounds 1, 3 and 4 (each within the scatter of the next); then compound 2.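

In this assay, putting 4-methylpiperidin-1-yl in place of 3-fluorophenyl on an aromatic carbon of the five-membered aromatic ring gives a 1.6-fold higher number from compound 3 to compound 4 (0.20 log units; within the scatter), a step within the scatter, so no order can be read between the two compounds. Among the earlier compounds, this carbon carried only phenyl or 3-fluorophenyl, so the new result is the first to show that a non-aromatic ring with a ring nitrogen and a hydrogen-bond acceptor can stand here with a value that these numbers do not separate from that of the aromatic group. No measurement shown here explains why the two groups read alike.

The compounds shown leave open whether the methyl on the piperidine counts for anything, and how the unsubstituted piperidin-1-yl, morpholin-4-yl or an open-chain amine such as dimethylamino would read at this carbon. They also leave open whether the same exchange would read alike on the partly saturated core of compound 1, where phenyl stands at this place, since this one pair rests on the core of compound 3 alone.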